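This account rests on a few compounds, and the source may have more. Where it says the series, first, only, none or still open, it means among the compounds named here.

Compound 1 `CN1CCC(C(=O)Nc2cccc(Nc3ncc(F)c(Nc4ccc(F)cc4)n3)c2)CC1`: 1330 nM
Compound 2 `O=C(Nc1cccc(Nc2ncc(F)c(Nc3ccc(F)cc3)n2)c1)c1ccccc1`: 37800 nM

For the measured compounds named here, in a functional assay on A549 cells (Homo sapiens) for antiproliferative activity, read by sulforhodamine B assay, with a stated time of 3 days (on this read-out higher numbers stand for weaker inhibition of growth and lower numbers for stronger inhibition of growth), compound 2, at 37800 nM, holds the higher of the two numbers so far. Compound 3 `CN(C)CC(=O)Nc1cccc(Nc2ncc(F)c(Nc3ccc(F)cc3)n2)c1` has (dimethylamino)methyl in place of phenyl on a carbonyl carbon. Going by the values given here, one measured step bears on this: a 28-fold higher number from compound 1 to compound 2 (1.45 log units; beyond the scatter), where phenyl replaced 1-methylpiperidin-4-yl. Compound 3 likewise drops the phenyl for a group containing nitrogen, but a different, ringless one, so a large fall in this assay is expected, perhaps short of that whole distance. The estimated step is a 13-fold lower number from compound 2 to compound 3 (1.10 log units; beyond the scatter). Compound 3 is expected at 3000 nM, within an estimated range of 800 nM to 12000 nM.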

Compound 3, concentration for 50% growth inhibition: 1180 nM
Compound 3: the middle estimate sits 2.5-fold (0.41 log units) above what was measured, and the stated range covers the measured number.
By their numbers in this assay, from the lowest: compounds 3 and 1 (each within the scatter of the next); then compound 2.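

In this assay, this carbonyl carbon accepts a small ringless group as well as a ring: a 32-fold lower number from compound 2 to compound 3 (1.51 log units; beyond the scatter), which undoes the whole loss seen with phenyl. Set against 1-methylpiperidin-4-yl, (dimethylamino)methyl gives a 1.1-fold lower number from compound 1 to compound 3 (0.05 log units; within the scatter), so the ring of compound 1 is not required for its number on this read-out. No measurement at hand explains the difference from phenyl. Still open, from the compounds shown here alone, is whether the nitrogen itself matters, a question that a plain ethyl group could address. Going by these compounds, a longer chain ending in dimethylamino also remains open.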